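The source may report more compounds than this note shows. Statements on the series, on what has been measured and on what is new or still open speak of the compounds shown alone.

Working notes on the amide series. Of the compounds shown here, three sharing one core have been measured. Compound 1 `COc1ccc2c(=O)c(/C=C/C(=O)Nc3cccc(C)c3)coc2c1` gives 15500 nM in a functional assay on Huh-7 cells (Homo sapiens) for inhibition, read by MTT assay, with a stated time of 48 h; on this read-out lower numbers stand for stronger inhibition and higher numbers for weaker inhibition. Compound 2 `COc1ccc2c(=O)c(/C=C/C(=O)NCc3ccc(F)cc3)coc2c1` gives 21000 nM in this assay, and the step of a 1.4-fold higher number from compound 1 to compound 2 (0.13 log units; within the scatter) shows the two anilide-versus-benzylamide variants sitting together. Compound 3 `COc1ccc(NC(=O)/C=C/c2coc3cc(OC)ccc3c2=O)cc1` is different: in this assay compound 3 gives > 100000 nM, which is a limit of the assay and not a number. Compound 3 therefore stands at the weak end of what has been seen, and its position rests on (the limit of > 100000 nM in this assay, at which 1 of the 3 values shown sits). The two steps into it, an at least 6.4-fold higher number from compound 1 to compound 3 (0.80 log units; beyond the scatter) and an at least 4.7-fold higher number from compound 2 to compound 3 (0.67 log units; beyond the scatter), are both beyond the scatter.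

Compound 4 `COc1ccc2c(=O)c(/C=C/C(=O)Nc3ccc(Cl)cc3)coc2c1` is the next variant. Relative to compound 3 the change is chloro in place of methoxy on an aromatic carbon. Among the compounds with values here, no measured step exchanges chloro for methoxy directly; the only steps that bear on this are those into compound 3, and both of them moved the number upward toward the limit. Moving away from compound 3 is expected to reverse part of that, so the step of an at least 2.5-fold lower number from compound 3 to compound 4 (0.39 log units; beyond the scatter) is expected to fall in the direction of a lower number. The expected value for compound 4 is 40000 nM, with the range from 12000 nM to 150000 nM.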

Compound 4, half-maximal inhibitory concentration: 37100 nM
Compound 4: the middle estimate sits 1.1-fold (0.03 log units) above what was measured; measured number inside the range.
By their numbers in this assay, from the lowest: compounds 1, 2 and 4 (each within the scatter of the next, the first and the last beyond it). At a limit, above all of these: compound 3.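

Within the data shown here, the step of an at least 2.6-fold lower number from compound 3 to compound 4 (0.43 log units; beyond the scatter) is the first in this assay in which the aromatic ring on the amide nitrogen stays and only the group on its carbon, para to a large group, changes, so this place is now seen to respond to the exchange of methoxy for chloro. With chloro at that place, the anilide no longer stands apart from the other amides in the same way: the step of a 1.8-fold higher number from compound 2 to compound 4 (0.25 log units; within the scatter) lies within the scatter, while the step of a 2.4-fold higher number from compound 1 to compound 4 (0.38 log units; beyond the scatter) lies beyond it and is modest, so compound 1 keeps the lowest number of the measured compounds only relative to compound 4, not to compound 2. Compound 3 carries a limit of the assay and not a number, so the step out of it gives a bound and not a size: the limit of > 100000 nM in this assay, at which 1 of the 4 values shown sits.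

Among these compounds, still open is whether methoxy alone stands out at this place, since only two groups have been compared there, and an amine or a carboxylic acid on the same carbon would test that. Also open, going by these compounds, is how a longer chain on the amide nitrogen would read against 4-chlorophenyl and 4-fluorobenzyl.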